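A few compounds are considered here, and "the series" means these few. Any claim that something is new, unique, unknown or untested is made for them only; others in the source may bear on it.

Going by the values given here, in a functional assay on the whole organism with Mus musculus as the target (on this read-out higher numbers stand for an effect only at larger amounts of compound and lower numbers for an effect already at smaller amounts), compound 1 (`COc1cc2c(cc1OC)C(c1ccc(N)cc1)=NN=C(S)C2`) gives 6.3 umol/kg and so holds the lower of the two numbers measured so far. Compound 2 (`COc1cc2c(cc1OC)C(c1ccc(N)cc1)=NNC(=O)C2`) gives 15 umol/kg and thus needs a larger dose, a gap that lies beyond the usual scatter. The next compound to be tested is compound 3 (`COc1cc2c(cc1OC)C(c1ccc(Cl)cc1)=NN=C(S)C2`). It keeps the core of compound 1 and carries chloro in place of amino on an aromatic carbon. Among the compounds with values here, no measured pair shows this exchange, so the expectation rests on little evidence and the range must stay wide. With compound 1 at 6.3 umol/kg as the lower of just two numbers, a move toward a higher number in this assay seems more likely than a further drop. The expected change is moderate: a 2.9-fold higher number from compound 1 to compound 3 (0.46 log units; beyond the scatter) is the estimated step. The estimated value for compound 3 is 18 umol/kg (range 6 umol/kg to 55 umol/kg).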

Compound 3, dose for half-maximal effect: 82.4 umol/kg
The estimate for compound 3 lay 4.6-fold (0.66 log units) below the measured number; measured number above the stated range.
By their numbers in this assay, from the lowest: compound 1; then compound 2; then compound 3.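

Until now this position had not varied, since compound 1 and compound 2 both carry amino there. In this assay, changing 4-aminophenyl to 4-chlorophenyl gives a 13-fold higher number from compound 1 to compound 3 (1.12 log units; beyond the scatter), so with the core of compound 1 held constant, this single-atom exchange on the aromatic ring is enough to produce a large change in the dose required. The data offer no measurement that explains this shift.

As far as these compounds go, one exchange cannot separate the loss of amino from the arrival of chloro, so it remains open which of the two drives the step. A hydroxyl, methylamino or fluoro group at this place would help to separate them, as would the same chloro exchange on compound 2, which would show whether the step carries over to that core.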